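Adding Fluorine to the Phenyl Ring of Compound 1

The compounds below may be only part of what the source reports. "The series", "measured", "known", "first", "only" and "open" are said of these compounds alone.

Compound 1 `CS(=O)(=O)c1ccc(N2N=C(c3ccccc3)CCC2=O)cc1` was tested in a functional assay on the whole organism (strain Wistar) for inhibition, with Rattus norvegicus as the target, read by paw edema, with stated times of 30 min and 3 h, at a dose of 0.05 mmol/kg by the oral route (on this read-out lower numbers stand for less inhibition and higher numbers for more inhibition at the one dose given (going by the name of the read-out)), where compound 1 gives 26.6%. On that number compound 1 stands level with compound 2 `CS(=O)(=O)c1ccc(N2N=C(c3ccc(Cl)c(Cl)c3)CCC2=O)cc1`, which gives 26.6%; together they are the lowest of the three measured values. Compound 3 `CS(=O)(=O)c1ccc(N2N=C(c3ccc(O)c(Cl)c3)CCC2=O)cc1` gives 43.3%, the highest of the three. The step of no change at the digits printed from compound 1 to compound 2 (within the scatter) stays within the scatter, whereas a number 16.7 percentage points higher from compound 1 to compound 3 (beyond the scatter) and a number 16.7 percentage points higher from compound 2 to compound 3 (beyond the scatter) are each modest rises.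

Compound 4 `CS(=O)(=O)c1ccc(N2N=C(c3ccc(F)cc3)CCC2=O)cc1` differs from compound 1 by fluoro in place of hydrogen on an aromatic carbon. Among the measured compounds shown here, no measured step introduces fluoro alone, so the nearest guide is the step that adds only chloro groups, no change at the digits printed from compound 1 to compound 2 (within the scatter), which moved nothing beyond the scatter; the rises seen in a number 16.7 percentage points higher from compound 1 to compound 3 (beyond the scatter) and a number 16.7 percentage points higher from compound 2 to compound 3 (beyond the scatter) both involve the hydroxy group, which compound 4 does not carry. The expected step is therefore a number 3.4 percentage points higher from compound 1 to compound 4 (within the scatter), nothing beyond the scatter. The estimate for compound 4 is 30%, ranging from 15% to 45%.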

Compound 4, a percentage reported as inhibition, in the whole organism at one dose (the size of the read-out at that dose, not a potency): 60%
Compound 4: middle estimate off by 30 percentage points, on the low side, outside the stated range (above it).
By their numbers in this assay, from the lowest: compounds 1 and 2 (each within the scatter of the next); then compound 3; then compound 4.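

In this assay, fluoro in place of hydrogen on an aromatic carbon, para to a large group, gives a number 33.4 percentage points higher from compound 1 to compound 4 (beyond the scatter), so this position responds to a single new atom, which the chloro-only step had not shown. The 4-fluorophenyl compound also stands clear of both earlier substituted compounds, with a number 16.7 percentage points higher from compound 3 to compound 4 (beyond the scatter) and a number 33.4 percentage points higher from compound 2 to compound 4 (beyond the scatter), so a rise beyond the scatter here does not need a hydroxy group. No measurement at hand bears on why this one atom moves the read-out so far.

As far as these compounds go, whether the rise is particular to fluoro or would also follow chloro alone, methoxy, an amine or a carboxylic acid at this place stays open. Also open, from the compounds shown here alone, is what fluoro would do on the other carbons of this ring.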